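From nitro to fluoro in an antiproliferative series

The compounds below may be only part of what the source reports. "The series", "measured", "known", "first", "only" and "open" are said of these compounds alone.

Compound 1 `COc1cc(OC)c2sc(-c3ccc(N/C=C\C(=O)c4ccc(OC)c([N+](=O)[O-])c4)c(C)c3)nc2c1` gives 13900 nM
Compound 2 `COc1cc(OC)c2sc(-c3ccc(N/C=C\C(=O)c4ccc(OC)c([N+](=O)[O-])c4)cc3)nc2c1` gives 2900 nM
Compound 3 `COc1ccc(C(=O)/C=C\Nc2ccc(-c3nc4cc(OC)c(OC)c(OC)c4s3)cc2)cc1[N+](=O)[O-]` gives 15900 nM

In a functional assay on MIA PaCa-2 cells (Homo sapiens) for antiproliferative activity, read by sulforhodamine B assay, with a stated time of 48 h (on this read-out lower numbers stand for stronger inhibition and higher numbers for weaker inhibition), compound 2 has the lowest of the three numbers. Compound 4 `COc1cc(OC)c2sc(-c3ccc(N/C=C\C(=O)c4ccc(OC)c(F)c4)cc3)nc2c1` differs from it by one change, fluoro in place of nitro on an aromatic carbon (4-methoxy-3-nitrophenyl becomes 3-fluoro-4-methoxyphenyl). Among the measured compounds shown here, no measured step touches this group, so the evidence is indirect. Two steps elsewhere in the molecule offer a guide: a 4.8-fold lower number from compound 1 to compound 2 (0.68 log units; beyond the scatter) and a 5.5-fold higher number from compound 2 to compound 3 (0.74 log units; beyond the scatter) are both modest, and compound 2 is the lower end of each. A modest rise is therefore expected in this assay, with the direction uncertain. The expected move is a 1.7-fold higher number from compound 2 to compound 4 (0.24 log units; within the scatter) by this estimate. Compound 4 is expected at 5000 nM (estimated range 1300 nM to 18000 nM).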

Compound 4, half-maximal inhibitory concentration: 4300 nM
Estimate against measurement, compound 4: 1.2-fold (0.07 log units) above; the measured number falls inside the stated range.
By their numbers in this assay, from the lowest: compounds 2 and 4 (each within the scatter of the next); then compounds 1 and 3 (each within the scatter of the next).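

Among the compounds shown here, until now, no step had touched the nitro group on this ring. In this assay, fluoro in place of nitro gives a 1.5-fold higher number from compound 2 to compound 4 (0.17 log units; within the scatter), so within this pair the nitro group, ortho to a methoxy group, is not needed to keep the number at this level. Nothing measured here explains this outcome.

On these data alone, whether an amine, a nitrile or a carboxylic acid at this position would behave the same stays open. So does whether fluoro would do so on the cores of compound 1 and compound 3 .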